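The source may report more compounds than this note shows. Statements on the series, on what has been measured and on what is new or still open speak of the compounds shown alone.

Compound 2 `O=C(NNc1nc(-c2ccccc2)c[se]1)c1ccccc1` and compound 1 `CC(=O)N(/N=C/c1ccc(Cl)cc1)c1nc(-c2ccccc2)c[se]1` share the same core and were both tested in a functional assay on HepG2 cells (Homo sapiens) for cytotoxicity, read by XTT assay, with a stated time of 72 h; on this read-out higher numbers stand for weaker inhibition and lower numbers for stronger inhibition. In this assay compound 1 gave only the limit of > 62000 nM, not a number. Compound 2 likewise gave only the limit of > 73000 nM in this assay. So compound 2 stands at a limit, (the limit of > 73000 nM in this assay, at which 1 of the 2 values shown sits), and compound 1 stands at a neighbouring limit, (the limit of > 62000 nM in this assay, at which 1 of the 2 values shown sits); neither shows a measured strength of inhibition, and nothing can be said about any order between them.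

Compound 3 `O=C(NNc1nc(-c2ccccc2)c[se]1)c1ccc(Cl)cc1` is not yet measured. It differs from compound 2 by chloro in place of hydrogen on an aromatic carbon, para to a large group. Among the measured compounds shown here, no measured pair shows what this change does in this assay, so there is no measured step to lean on.

The step from compound 2 to compound 3, a step that the limit leaves unreadable from compound 2 to compound 3, is expected to be none beyond the scatter, because compound 2 sits at the limit of > 73000 nM in this assay, at which 1 of the 2 values shown sits. Compound 3 is therefore estimated at 80000 nM, within a range from 30000 nM to 200000 nM, most likely reported again as a limit rather than a number.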

Compound 3, half-maximal inhibitory concentration: 62900 nM
Beside the measured number, compound 3's estimate is 1.3-fold (0.10 log units) above it; the range from low to high includes it.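

In this assay compound 3 is the only one of the three compounds shown to give a true number rather than a limit, 62900 nM, so this series now has one measured point to compare others with. Going from phenyl to 4-chlorophenyl, with chloro on an aromatic carbon para to a large group, gives an at least 1.1-fold lower number from compound 2 to compound 3 (0.06 log units; that floor lies within the scatter), so this pair shows no change that can be told apart from ordinary assay noise. The true size of the step may be larger, but it cannot be read because compound 2 has only a limit, not a number: the limit of > 73000 nM in this assay, at which 1 of the 3 values shown sits.

Going by these compounds, it remains open whether a different group at the same place, such as an amine or a carboxylic acid, would give a number clearly lower than that of compound 3. Also open, on these data alone, is what chloro does elsewhere on this ring, and compound 1 cannot settle this, since it differs from compound 3 in more than one place.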